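This account rests on a few compounds, and the source may have more. Where it says the series, first, only, none or still open, it means among the compounds named here.

In a functional assay on the whole organism with Rattus norvegicus as the target (a lower number here means that less compound is needed, a higher number that more compound is needed for the effect), compound 1 `N=c1sc2cc(OC(F)(F)F)ccc2n1CC(=O)O` gives > 10 mg/kg, which is a limit of the assay and not a number. Going by the values given here, compound 2 `CSCCCn1c(=N)sc2cc(OC(F)(F)F)ccc21` gives 4.2 mg/kg, the only true number so far. Among the compounds with values here, its standing can be judged only against the single limit of compound 1. Within the data shown here, the one measured step is an at least 2.3-fold lower number from compound 1 to compound 2 (0.37 log units; beyond the scatter), and it came from putting 2-(methylsulfanyl)ethyl in place of carboxy on the chain.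

Compound 3 `CN(C)CCn1c(=N)sc2cc(OC(F)(F)F)ccc21` now changes that chain again, with dimethylamino in place of (methylsulfanyl)methyl on a saturated chain carbon, two bonds along the chain from an aromatic nitrogen. Among the measured compounds shown here, the measured step is the only guide here, and a weak one, as it removed a carboxy group that neither compound 2 nor compound 3 carries. The two groups now being exchanged match in what is counted above, so no step beyond the usual scatter is expected, and the estimated step is a 1.2-fold higher number from compound 2 to compound 3 (0.08 log units; within the scatter). For compound 3 the expected value is 5 mg/kg, with an estimated range from 1.5 mg/kg to 15 mg/kg.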

Compound 3, dose for half-maximal effect: 2.3 mg/kg
Compound 3: the middle estimate sits 2.2-fold (0.34 log units) above what was measured; the range from low to high includes it.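

Putting dimethylamino in place of (methylsulfanyl)methyl, on a saturated chain carbon, two bonds along the chain from an aromatic nitrogen, gives a 1.8-fold lower number from compound 2 to compound 3 (0.26 log units; within the scatter) in this assay, so a sulfur-bearing and a nitrogen-bearing group with the same count of heavy atoms cannot be told apart at this place. Compound 1, which carries the carboxy group, stands at a limit of the assay and not at a number: the limit of > 10 mg/kg in this assay, at which 1 of the 3 values shown sits A second chain now also separates from the carboxy compound, with an at least 4.3-fold lower number from compound 1 to compound 3 (0.63 log units; beyond the scatter), so the earlier gain is no longer tied to the 3-(methylsulfanyl)propyl chain alone and also appears with 2-(dimethylamino)ethyl.

The compounds shown leave open whether the chain end needs a sulfur or nitrogen atom at all, as a plain propyl chain would show, and whether a primary amine, an alcohol or a ring amine such as morpholine would fit there equally well. They also leave open how a longer chain carrying the dimethylamino group would compare with the 2-(dimethylamino)ethyl chain of compound 3.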